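Swapping a Bromophenyl Cap for a Phenylethenyl Cap

The source may hold more compounds than are shown below. What is called first, only, known or untested is meant among the compounds shown, and "the series" means these compounds.

Measured compounds:
compound 1, `CN(C)c1ccc(C(=O)N[C@@H](CCCCCC(=O)NO)C(=O)NCc2ccccc2)cc1`: 12000 nM
compound 2, `O=C(CCCCC[C@H](NC(=O)c1cc2ccccc2[nH]1)C(=O)NCc1ccccc1)NO`: 1260 nM
compound 3, `O=C(CCCCC[C@H](NC(=O)c1ccc(Br)cc1)C(=O)NCc1ccccc1)NO`: 5860 nM

In a functional assay on NFF cells (Homo sapiens) for antiproliferative activity (on this read-out lower numbers stand for stronger inhibition and higher numbers for weaker inhibition), compound 3 stands second highest of the three numbers; its nearer neighbour is reached by the step of a 2.0-fold lower number from compound 1 to compound 3 (0.31 log units; beyond the scatter) and its further neighbour by the step of a 4.7-fold higher number from compound 2 to compound 3 (0.67 log units; beyond the scatter). Compound 4, `O=C(/C=C/c1ccccc1)N[C@@H](CCCCCC(=O)NO)C(=O)NCc1ccccc1`, differs from compound 3 in one place: 2-phenylethenyl in place of 4-bromophenyl on a carbonyl carbon. Among the compounds with values here, no measured step exchanges a ring on this carbonyl for a phenylethenyl group, so the nearest guides are the cap changes a 9.5-fold lower number from compound 1 to compound 2 (0.98 log units; beyond the scatter) and a 4.7-fold higher number from compound 2 to compound 3 (0.67 log units; beyond the scatter), which show that the group on this carbonyl shifts the number by modest amounts. A modest step in this assay is therefore expected, with no firm direction, leaning toward a lower number. Compound 4 is expected at 4000 nM, between 1500 nM and 11000 nM, which would mean a 1.5-fold lower number from compound 3 to compound 4 (0.17 log units; within the scatter).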

Compound 4, half-maximal inhibitory concentration: 4010 nM
The estimate for compound 4 lay 1.0-fold (0.00 log units) below the measured number, and the stated range covers the measured number.
By their numbers in this assay, from the lowest: compound 2; then compounds 4 and 3 (each within the scatter of the next); then compound 1.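

In this assay the 2-phenylethenyl group on this carbonyl sits level with 4-bromophenyl (a 1.5-fold lower number from compound 3 to compound 4 (0.16 log units; within the scatter)), so a ring bonded directly to the carbonyl is not required to reach this level. The same group still gives a weaker result than 1H-indol-2-yl (a 3.2-fold higher number from compound 2 to compound 4 (0.50 log units; beyond the scatter)) and a stronger one than 4-(dimethylamino)phenyl (a 3.0-fold lower number from compound 1 to compound 4 (0.48 log units; beyond the scatter)). No measurement here accounts for these differences.

Whether the double bond itself matters stays open, since the saturated 2-phenylethyl chain is not among these compounds. Also open, going by these compounds, is how an amine on the phenyl ring of the 2-phenylethenyl group would read.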